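The source may hold more compounds than are shown below. What is called first, only, known or untested is meant among the compounds shown, and "the series" means these compounds.

Of the compounds shown here, two sharing one core have been measured. In an ADME assay on microsomes from liver (Mus musculus) for metabolic stability, with a stated time of 30 min, tested at 1 uM (a lower number here means that less of the compound is left, a higher number that more of the compound is left), compound 1 `N#C/N=C(\NCc1ccc(S(=O)(=O)c2ccccc2)cc1)Nc1cccnc1` gives 14%, and compound 2 `COc1cccc(S(=O)(=O)c2ccc(CN/C(=N\C#N)Nc3ccncc3)cc2)c1` gives 58%. Compound 2 stands highest of the two numbers; its nearest neighbour is compound 1, which lies lower by a gap beyond the scatter. Compound 3 `N#C/N=C(\NCc1ccc(S(=O)(=O)c2cccc(C(F)(F)F)c2)cc1)Nc1ccncc1` has not yet been measured. It differs from compound 2 in one place: trifluoromethyl in place of methoxy on an aromatic carbon of a six-membered aromatic ring of carbon only, meta to a large group. For the measured compounds named here, no pair of measured compounds shows this change, so its size in this assay is not known from the data; a step within the scatter, or at most a modest rise, is expected. The step from compound 2 to compound 3 is estimated as a number 4 percentage points higher from compound 2 to compound 3 (within the scatter). For compound 3 the expected value is 62%, with a range from 38% to 86%.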

Compound 3, percent of the compound remaining in the Mus musculus assay: 74%
For compound 3 the middle estimate is 12 percentage points below the measured one, and the stated range covers the measured number.
By their numbers in the Mus musculus assay, from the lowest: compound 1; then compound 2; then compound 3.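

For the compounds shown here, replacing 3-methoxyphenyl with 3-(trifluoromethyl)phenyl gives the first direct reading of a change at this aromatic carbon: in the Mus musculus assay compound 2 gives 58% and compound 3 gives 74%, and the step is a number 16 percentage points higher from compound 2 to compound 3 (beyond the scatter), so the group held here affects how much compound is left. In a physicochemical assay for solubility, with a stated time of 24 h (a lower number here means a less soluble compound, a higher number a more soluble compound), compound 2 gives 51000 nM and compound 3 gives 28000 nM, and the same change gives a 1.8-fold lower number from compound 2 to compound 3 (0.26 log units; within the scatter), so the shift in compound remaining comes without a shift in solubility beyond the usual scatter. Nothing available explains why this swap has the effect it does.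

Going by these compounds alone, only two groups have been compared at this position, so it remains open whether a methyl group, a chlorine atom or an amine would behave like trifluoromethyl or like methoxy. As far as these compounds go, whether the same swap would have a similar effect on a different core also remains unknown.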